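This account rests on a few compounds, and the source may have more. Where it says the series, first, only, none or still open, it means among the compounds named here.

Working notes on the series. In a functional assay on the whole organism (strain Swiss) with Mus musculus as the target, in the maximal electroshock model, with a stated time of 0.25 h, at a dose of 300 mg/kg by the intraperitoneal route (a higher number here means a stronger effect of the compound at the dose given, a lower number a weaker effect), compound 1 `COCC(C(=O)N1CCN(c2cccc(C(F)(F)F)c2)CC1)N1C(=O)CCC1=O` gives 25%, level at the digits shown with compound 3 `CCC(C(=O)N1CCN(c2cccc(OC)c2)CC1)N1C(=O)CCC1=O`, which gives 25%; together these are the lowest of the three numbers, and compound 2 `CC(C(=O)N1CCN(c2ccccc2F)CC1)N1C(=O)CCC1=O` sits far higher, as compound 2 gives 100%. Compound 4 `CC(C(=O)N1CCN(c2cccc(C(F)(F)F)c2)CC1)N1C(=O)CCC1=O` differs from compound 1 in one place: hydrogen in place of methoxy on a saturated chain carbon, two bonds along the chain from an amide-type nitrogen in a ring and a carbonyl carbon. For the measured compounds named here, no measured pair makes this exact change. Going by the values given here, the expectation leans on compound 2, the only compound carrying a methyl on that saturated chain carbon, because its value in this assay is 100%. An upward step from compound 1 is expected in this assay, beyond the scatter, a number 30 percentage points higher from compound 1 to compound 4 (beyond the scatter). Compound 4 is therefore estimated at 55%, within 20% to 95%.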

Compound 4, a percentage reported as activity, at one dose (the size of the read-out at that dose, not a potency): 75%
Estimate against measurement, compound 4: 20 percentage points below; the range from low to high includes it.
By their numbers in this assay, from the lowest: compounds 1 and 3 (each within the scatter of the next); then compound 4; then compound 2.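

In this assay, the methoxy on this saturated chain carbon now has a single-place reading: hydrogen in its place gives a number 50 percentage points higher from compound 1 to compound 4 (beyond the scatter). The methoxymethyl to methyl change alone therefore moves the read-out by a large amount at this dose, which compounds differing in several places could not show. Nothing measured here accounts for the size of this step.

On these data alone, whether the step carries over to the ring substituents of compound 2 and compound 3 remains open. So does the outcome with a hydroxyl, an amine or a propyl chain at this position.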